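The compounds below may be only part of what the source reports. "The series", "measured", "known", "first", "only" and "open" are said of these compounds alone.

Measured so far in a functional assay on HeLa cells (Homo sapiens) for cytotoxicity, read by WST assay, with a stated time of 48 h; a higher number here means a weaker inhibitor, a lower number a stronger inhibitor:
Compound 1 `O[C@@H](c1ccccc1)[C@H]1CO[C@H](c2ccccc2)[C@@H](C/C=C/c2ccncc2)C1` gives > 100000 nM, which is a limit of the assay and not a number.
Compound 2 `COc1cccc([C@H]2OC[C@H]([C@@H](O)c3ccc(OC)c(OC)c3)C[C@@H]2C/C=C/c2ccc(OC)c(OC)c2)c1` gives 21800 nM.
Compound 3 `COc1ccc(/C=C/C[C@H]2C[C@@H]([C@@H](OC(C)=O)c3ccc(OC)c(OC)c3)CO[C@@H]2c2ccc(OC)c(OC)c2)cc1OC` gives > 100000 nM, again a limit of the assay.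

Compound 1 therefore stands at the limit of this assay, and no measured number exists for it. Within the three compounds shown, only compound 2 carries a measured value, while compound 1 and compound 3 both sit at the limit of > 100000 nM in this assay, at which 2 of the 3 values shown sit. Compound 4 `O[C@@H](c1ccccc1)[C@H]1CO[C@H](c2ccccc2)[C@@H](C/C=C/c2ccccc2)C1` differs from compound 1 in one place: phenyl in place of pyridin-4-yl on a double-bonded chain carbon bound to a double-bonded chain carbon. For the measured compounds named here, no step between two measured compounds that differ in only one place is at hand, so the size of this exchange in this assay cannot be read from the series itself. Because compound 1 shows only > 100000 nM, the expectation for compound 4 rests on that limit alone. Compound 4 is expected to stay near the same limit, with an expected step of a number no higher from compound 1 to compound 4 (the limit leaves the size open), that is none beyond the scatter. The estimate for compound 4 is 100000 nM, expected within 30000 nM to 300000 nM.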

Compound 4, half-maximal inhibitory concentration: 6060 nM
For compound 4 the middle estimate is 17-fold (1.22 log units) above the measured one; the whole stated range lies above it.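

In this assay, for the compounds shown here, 2-phenylethenyl in place of 2-(pyridin-4-yl)ethenyl gives an at least 16-fold lower number from compound 1 to compound 4 (1.21 log units; beyond the scatter), the first step that can be read at a single place, and it shows that this place bears on the read-out. The exchange swaps a ring nitrogen and its hydrogen-bond acceptor for a ring carbon, while the number of heavy atoms stays the same. Compound 1 stands at a limit of the assay, so the step is a bound and its full size stays unread: the limit of > 100000 nM in this assay, at which 2 of the 4 values shown sit.

As far as these compounds go, compound 2 and compound 3 differ from the other compounds in more than one place, so no further steps can be read, and the contribution of their methoxy and acetate groups stays open. Also open, from the compounds shown here alone, is how pyridin-3-yl, or a phenyl carrying a dimethylamino group or a carboxylic acid, would behave in this place.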